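One amide swap with only limits to go on

The source may report more compounds than this note shows. Statements on the series, on what has been measured and on what is new or still open speak of the compounds shown alone.

Two results so far in a physicochemical assay for solubility, read by HPLC, using the shake flask method, in phosphate buffer, measured as kinetic solubility, with a stated time of 20 h, at pH 6.5 (on this read-out higher numbers stand for higher solubility and lower numbers for lower solubility), are shown here
- Compound 1 `O=C(c1ccnc(Nc2nc3cnc(Nc4ccc(F)c(C(F)(F)F)c4)cc3[nH]2)c1)N1CCN(C2CC2)CC1` gives < 5000 nM (a limit)
- Compound 2 `O=C(c1ccnc(Nc2nc3cnc(Nc4ccc(F)c(F)c4)cc3[nH]2)c1)N1CCN(C2CC2)CC1` gives < 5000 nM (a limit)

Compound 2 has no exact number on this read-out, only its limit of < 5000 nM as the reported result.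

Compound 3 `C[C@@H]1CN(C(=O)c2ccnc(Nc3nc4cnc(Nc5ccc(F)c(F)c5)cc4[nH]3)c2)C[C@H](C)O1` differs from compound 2 in one place, (2,6-dimethylmorpholin-4-yl in place of 4-cyclopropylpiperazin-1-yl on a carbonyl carbon), where 2,6-dimethylmorpholin-4-yl takes the place of 4-cyclopropylpiperazin-1-yl on a carbonyl carbon.

Going by the values given here, the only measured step is a step that the two limits leave unreadable from compound 1 to compound 2 and it concerns a different place, so it offers no size to carry over. The whole measured picture is the limit of < 5000 nM in this assay, at which 2 of the 2 values shown sit, and gives neither a size nor a direction. The expectation therefore rests on compound 2 and its limit of < 5000 nM alone, and no step beyond the usual scatter is expected. The estimated step is a step that the limit leaves unreadable from compound 2 to compound 3 and remains a rough guess. Compound 3 may well return only a limit again in this assay as well. For compound 3 the expected solubility is 3000 nM, and the estimated range runs from 800 nM to 6000 nM.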

Compound 3, solubility: < 5000 nM
Compound 3: a limit, no number; the forecaster's own chance of this, stated with the estimate: 80%; the middle value is on the limit's open side.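

Compound 2 and compound 3 both return only a limit in this assay, not a number, so no step can be read between them. The compounds shown leave open how soluble each one actually is and whether changing either group makes any difference, as the whole picture is a single shared limit: the limit of < 5000 nM in this assay, at which 3 of the 3 values shown sit.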